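Swapping the amine on a thiocarbonyl carbon of a benzamide series

The source may hold more compounds than are shown below. What is called first, only, known or untested is meant among the compounds shown, and "the series" means these compounds.

Of the compounds shown here, three that share one core have been measured in a functional assay on HeLa cells (Homo sapiens) for antiproliferative activity, read by CCK-8 assay, with a stated time of 72 h, tested at 8 uM; a higher number here means a stronger effect of the compound at the concentration tested, a lower number a weaker effect. Compound 1 `CN(C(=S)SCc1ccc(C(=O)Nc2ccccc2N)cc1)c1cccnc1` gives 70.5% there. Compound 2 `Nc1ccccc1NC(=O)c1ccc(CSC(=S)N2CCN(c3ccc(F)cc3)CC2)cc1` gives 64.5%, and compound 3 `CCN(Cc1ccncc1)C(=S)SCc1ccc(C(=O)Nc2ccccc2N)cc1` gives 77.7%. Compound 1 thus sits between the other two, and its distance to each of them lies within the scatter of the measurement: the step of a number 7.2 percentage points higher from compound 1 to compound 3 (within the scatter) is small, and the gap to compound 2 is smaller still.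

Compound 4 `CN1CCN(C(=S)SCc2ccc(C(=O)Nc3ccccc3N)cc2)CC1` has not been measured. It differs from compound 1 in one place: 4-methylpiperazin-1-yl in place of methyl(pyridin-3-yl)amino on a thiocarbonyl carbon.

Within the data shown here, the one measured step that bears on this change is the one from compound 1 to compound 3, which also exchanges the amino group on the thiocarbonyl carbon and moves the read-out by a number 7.2 percentage points higher from compound 1 to compound 3 (within the scatter), within the scatter. Compound 2, which carries yet another group at the same place, gives a value close to that of compound 1 as well. The data therefore suggest that changes at this position leave the read-out roughly where it is. The author expects the step of a number 2.5 percentage points lower from compound 1 to compound 4 (within the scatter) to stay within the scatter. Compound 4 is therefore estimated at 68%, with a likely range from 55% to 80%.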

Compound 4, a percentage reported as inhibition, at one concentration (the size of the read-out at that concentration, not a potency): 75.7%
Compound 4: the middle estimate sits 7.7 percentage points below what was measured; low and high end bracket the measured number.
By their numbers in this assay, from the lowest: compounds 2, 1, 4 and 3 (each within the scatter of the next, the first and the last beyond it).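

In this assay the non-aromatic 4-methylpiperazin-1-yl ring on the thiocarbonyl carbon performs much like the aromatic groups it was compared with: the printed steps are a number 5.2 percentage points higher from compound 1 to compound 4 (within the scatter) and a number 2 percentage points lower from compound 3 to compound 4 (within the scatter) and neither separates the compounds, so among these compounds an aromatic ring in this amine is not needed to keep the read-out at this level. Among these compounds, compound 4 also supplies the first single-place step in the set that lies beyond the scatter, and it arises further out on the same amine: with methyl in place of 4-fluorophenyl on an amine nitrogen in a ring, the change is a number 11.2 percentage points higher from compound 2 to compound 4 (beyond the scatter) and it rests on this one pair alone. No measurement shown here accounts for any of these numbers.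

From the compounds shown here alone, whether the step from 4-fluorophenyl to methyl would hold for an unsubstituted phenyl, a longer alkyl chain or a carboxylic acid on that ring nitrogen remains open. Since the read-out comes from a single concentration, these compounds also leave open how their potencies compare, which could differ from what these percentages suggest.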